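A few compounds are considered here, and "the series" means these few. Any claim that something is new, unique, unknown or untested is made for them only; others in the source may bear on it.

Two measured compounds share one core and differ only in the group attached through an oxygen to the outer benzene ring. Compound 1 `O=C1N=C(c2ccc3ccccc3c2)S/C1=C\c1ccc(Oc2ccccc2)cc1` carries a phenoxy group there; in an assay on cells for inhibition of Polyunsaturated fatty acid 5-lipoxygenase (Homo sapiens), read by HPLC, with stated times of 15 min and 10 min (on this read-out lower numbers stand for stronger inhibition and higher numbers for weaker inhibition), compound 1 gives 480 nM. Compound 2 `COc1ccc(/C=C2\SC(c3ccc4ccccc4c3)=NC2=O)cc1` carries a methoxy group in the same place, and in this assay compound 2 gives 120 nM. Among the compounds with values here, the single step between measured compounds, a 4.0-fold lower number from compound 1 to compound 2 (0.60 log units; beyond the scatter), shows that the smaller group goes with the stronger inhibition. Among the two numbers, compound 2 therefore stands at the lowest value, with compound 1 as its only neighbour at a higher one.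

Compound 3 `COc1ccc(/C=C2\SC(c3ccc4ccccc4c3)=NC2=O)cc1O` has not yet been measured. It differs from compound 2 by hydroxy in place of hydrogen on an aromatic carbon. Within the data shown here, no measured step involves a hydroxy group, and the one known step concerns the size of the group on the oxygen rather than a new substituent on the ring, so it does not bear directly on this change. With nothing pointing either way, a step within the scatter is expected, a 1.2-fold lower number from compound 2 to compound 3 (0.08 log units; within the scatter). For compound 3 the estimated value is 100 nM, within a range from 30 nM to 350 nM.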

Compound 3, half-maximal inhibitory concentration: 780 nM
For compound 3 the middle estimate is 7.8-fold (0.89 log units) below the measured one; measured number outside the range, above it.
By their numbers in this assay, from the lowest: compound 2; then compounds 1 and 3 (each within the scatter of the next).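

On the six-membered aromatic ring of compound 2, the carbon ortho to a methoxy group is sensitive to substitution: hydroxy in place of hydrogen there gives a 6.5-fold higher number from compound 2 to compound 3 (0.81 log units; beyond the scatter) in this assay. Within the data shown here, until now, the only change seen was in the group carried on the oxygen, so this is the first sign that a new substituent on the ring itself also shifts the number, here toward weaker inhibition. Nothing in the data shown explains this loss, and its reason stays unknown.

The compounds shown leave open whether the weaker inhibition belongs to hydroxy in particular or to any group at this carbon, a question that a fluorine atom or an amine at the same place would help to settle. Also open, from the compounds shown here alone, is whether hydroxy at this carbon would give a step of similar size on the phenoxy compound 1, and how the number would respond to hydroxy at another carbon of the same ring.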